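The source may hold more compounds than are shown below. What is called first, only, known or untested is meant among the compounds shown, and "the series" means these compounds.

The measured compounds:
Compound 1, `Cc1[nH]cnc1CN1CCN(c2cccc(C#N)c2)C1=O`, gives 134 nM in a functional assay (Cavia porcellus) for antagonist activity at Serotonin 3 (5-HT3) receptor (Homo sapiens); a lower number here means a stronger inhibitor, a higher number a weaker inhibitor.
Compound 2, `Cc1[nH]cnc1CN1CCN(c2cccc([N+](=O)[O-])c2)C1=O`, gives 125 nM in this assay.

Within the data shown here, compound 2 has the lowest of these two numbers, but its nearest neighbour is compound 1, and the single measured step between them, a 1.1-fold lower number from compound 1 to compound 2 (0.03 log units; within the scatter), lies within the scatter, so no order between the two can be claimed. Compound 3, `Cc1[nH]cnc1CN1CCN(c2cccc(F)c2)C1=O`, is not yet measured. It differs from compound 2 by fluoro in place of nitro on an aromatic carbon. Among the measured compounds shown here, only one measured step bears on this exchange, and it touches the same aromatic carbon: when nitro replaced cyano there the number hardly moved, a 1.1-fold lower number from compound 1 to compound 2 (0.03 log units; within the scatter). For the measured compounds named here, no measured compound carries fluoro at that position, so the expectation rests on this one step alone. Going by the values given here, because the only exchange at this carbon, a 1.1-fold lower number from compound 1 to compound 2 (0.03 log units; within the scatter), stayed within the scatter, a step of no more than the scatter is expected in this assay, in either direction: a 1.2-fold higher number from compound 2 to compound 3 (0.08 log units; within the scatter). Compound 3 is therefore estimated at 150 nM, with a range from 60 nM to 400 nM.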

Compound 3, antagonist equilibrium constant: 88.3 nM
For compound 3 the middle estimate is 1.7-fold (0.23 log units) above the measured one, and the stated range covers the measured number.
By their numbers in this assay, from the lowest: compounds 3, 2 and 1 (each within the scatter of the next).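

In this assay this aromatic carbon has now carried three different groups, and both exchanges to fluoro stay within the scatter (a 1.4-fold lower number from compound 2 to compound 3 (0.15 log units; within the scatter); a 1.5-fold lower number from compound 1 to compound 3 (0.18 log units; within the scatter)), so the one earlier observation of little movement now extends to a second kind of exchange. This change is also larger in what is counted than the earlier one: nitro, with 3 heavy atoms and 2 hydrogen-bond acceptors, gives way to fluoro, with 1 heavy atom and 0 hydrogen-bond acceptors, and still no difference can be claimed between compound 2 and compound 3, so neither count separates these compounds in this assay. Nothing measured here accounts for the three groups reading alike.

Going by these compounds, all the groups shown sit on this one aromatic carbon, so it remains open whether an amine, a carboxylic acid or a longer chain there would also stay within the scatter. On these data alone, it is equally open whether plain hydrogen at that carbon, or fluoro on a different carbon of the same ring, would give a number like these.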